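Disulfide substituent and half-life in a thymidine series

The compounds below may be only part of what the source reports. "The series", "measured", "known", "first", "only" and "open" are said of these compounds alone.

Compound 1 `Cc1cn([C@H]2C[C@H](SSC(Cl)(Cl)Cl)[C@@H](CO)O2)c(=O)[nH]c1=O`: in a physicochemical assay for pharmacokinetics, at pH 7.2 (a higher number here means that the compound lasts longer, a lower number that the compound disappears faster), compound 1 gives < 0.0834 h, which is a limit of the assay.
Compound 2 `Cc1cn([C@H]2C[C@H](SSc3ccccc3[N+](=O)[O-])[C@@H](CO)O2)c(=O)[nH]c1=O`: compound 2 gives < 0.0834 h, also a limit.
Compound 3 `CCCCSS[C@H]1C[C@H](n2cc(C)c(=O)[nH]c2=O)O[C@@H]1CO`: compound 3 gives < 0.0834 h, again a limit.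

Compound 3 thus stands at the limit, and the two other values sit at the same limit, so no number separates the three. The change to compound 4 `CCCCCCSS[C@H]1C[C@H](n2cc(C)c(=O)[nH]c2=O)O[C@@H]1CO` is ethyl in place of hydrogen on a saturated chain carbon, four bonds along the chain from a sulfur. The steps that alter the group on the sulfur, a step that the two limits leave unreadable from compound 1 to compound 3 and a step that the two limits leave unreadable from compound 2 to compound 3, cannot be sized because the limit of < 0.0834 h in this assay, at which 3 of the 3 values shown sit, covers every value measured. No readable step therefore bears on this change, and a value at the limit is again expected. Compound 4 is estimated at 0.05 h, within 0.02 h to 0.15 h. Among the compounds with values here, the expected step that the limit leaves unreadable from compound 3 to compound 4 rests on no measured step.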

Compound 4, half-life: < 0.0834 h
Compound 4 was reported as a limit; the forecaster's own chance of this, stated with the estimate: 85%; the middle value is on the limit's open side.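

Compound 4 adds no readable step against compound 1, compound 2 or compound 3 in this assay, and all remain limits: the limit of < 0.0834 h in this assay, at which 4 of the 4 values shown sit.
The compounds shown leave open whether the group on the sulfur alters the half-life at all.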